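The compounds below may be only part of what the source reports. "The series", "measured", "known", "first", "only" and "open" are said of these compounds alone.

Measured compounds:
- compound 1, `CNc1nc(NCCCN(C)C)c2sc(-c3ccc(-n4cccn4)cc3)cc2n1`, in a physicochemical assay for solubility, at pH 2 (a higher number here means a more soluble compound, a lower number a less soluble compound), compound 1 gives 217 ug/mL
- compound 2, `CNc1nc(NCCCN(C)C)c2sc(-c3ccc(NS(C)(=O)=O)cc3)cc2n1`; in this assay compound 2 gives > 100 ug/mL, which is a limit of the assay and not a number
- compound 3, `CNc1nc(NCCCN(C)C)c2sc(-c3cncnc3)cc2n1`, in this assay compound 3 gives 214 ug/mL

Among the two numbers, compound 3 has the lower one, but its nearest neighbour, compound 1, sits within the scatter of it, so the two cannot be told apart. Among the measured compounds shown here, the only single-point step between measured compounds, a step that the limit leaves unreadable from compound 1 to compound 2, cannot be read because the limit of > 100 ug/mL in this assay, at which 1 of the 3 values shown sits, hides its size.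

Compound 4, `CNc1nc(NCCCN(C)C)c2sc(-c3ccccc3)cc2n1`, has not yet been measured. It differs from compound 3 by phenyl in place of pyrimidin-5-yl on an aromatic carbon. For the measured compounds named here, no measured step touches this kind of exchange; the one comparison of two aryl groups on the same core, compound 1 against compound 3, shows numbers within the scatter of each other. Going by the values given here, with no measured step bearing on the change, the expectation rests on that pair alone, and a step no larger than the scatter, perhaps a small fall, is expected as a 1.6-fold lower number from compound 3 to compound 4 (0.22 log units; within the scatter). For compound 4 in this assay a value of 130 ug/mL is therefore estimated, with a range from 45 ug/mL to 300 ug/mL.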

Compound 4, solubility: > 100 ug/mL
Compound 4: no number, only a limit (the forecaster's own chance of this, stated with the estimate: 30%); the middle value lies beyond the limit too.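

In this assay compound 4 gives > 100 ug/mL, a limit of the assay and not a number. Among the compounds shown here, no step from compound 1, compound 2 or compound 3 to compound 4 can be read, because of this: the limit of > 100 ug/mL in this assay, at which 2 of the 4 values shown sit. The compounds shown leave open whether compound 4 differs at all from compound 3 in this assay.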